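Swapping an aryl for a benzyl on the amine nitrogen

The source may report more compounds than this note shows. Statements on the series, on what has been measured and on what is new or still open speak of the compounds shown alone.

Of the compounds shown here, three built on one shared core have been tested in a functional assay on NCI-H1299 cells (Homo sapiens) for antiproliferative activity, read by MTT assay, with a stated time of 72 h; on this read-out lower numbers stand for stronger inhibition and higher numbers for weaker inhibition. Compound 1 `O=C(C1=C(O)C(=O)N(CCCn2ccnc2)C1c1ccc(Br)cc1)c1ccccc1` gives 20000 nM. Compound 2 `CCOC1=C(C(=O)c2ccccc2)C(c2ccc(Br)cc2)N(CCCn2ccnc2)C1=O` gives 28900 nM. Compound 3 `O=C(C1=C(Nc2ccc(Br)cc2)C(=O)N(CCCn2ccnc2)C1c1ccc(Br)cc1)c1ccccc1` gives 19300 nM, the lowest of the three numbers, although the gaps to the other two are small: the step of a 1.0-fold lower number from compound 1 to compound 3 (0.02 log units; within the scatter) and the step of a 1.5-fold lower number from compound 2 to compound 3 (0.18 log units; within the scatter) both fall inside the usual scatter of repeated measurements, so the three compounds cannot be told apart on these data.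

Compound 4 `O=C(C1=C(NCc2ccccc2)C(=O)N(CCCn2ccnc2)C1c1ccc(Br)cc1)c1ccccc1` has not yet been measured. It differs from compound 3 in one place: benzyl in place of 4-bromophenyl on an amine nitrogen. Among the measured compounds shown here, none of the measured steps change the group on that amine nitrogen. The two steps that end at compound 3 exchange a hydroxy or an ethoxy for the (4-bromophenyl)amino group and stay within the scatter, while the step of a 1.4-fold higher number from compound 1 to compound 2 (0.16 log units; within the scatter) also stays within the scatter. Every change made so far at this position of the core has left the read-out essentially unmoved, so no shift beyond the scatter is expected here either. Compound 4 is therefore estimated at 20000 nM, with a range from 8000 nM to 50000 nM, which means an expected step of a 1.0-fold higher number from compound 3 to compound 4 (0.02 log units; within the scatter).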

Compound 4, half-maximal inhibitory concentration: 25300 nM
For compound 4 the middle estimate is 1.3-fold (0.10 log units) below the measured one; low and high end bracket the measured number.
By their numbers in this assay, from the lowest: compounds 3, 1, 4 and 2 (each within the scatter of the next).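

In this assay, among the compounds shown here, this is the first change to the group on the amine nitrogen itself: benzyl replaces 4-bromophenyl, which removes the bromine while keeping one aromatic ring and the same count of heavy atoms, and the result is a 1.3-fold higher number from compound 3 to compound 4 (0.12 log units; within the scatter) and so the read-out does not separate the two groups. The benzylamino group also cannot be told apart from the groups it replaces on the double-bonded ring carbon, with a 1.3-fold higher number from compound 1 to compound 4 (0.10 log units; within the scatter) and a 1.1-fold lower number from compound 2 to compound 4 (0.06 log units; within the scatter) as the two steps, so a hydroxy, an ethoxy and both arylated or benzylated amines all give similar read-outs on this core. No measured data are available to explain why this position shows so little response.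

The swap changes two things at once, and a plain phenyl or a bromobenzyl group on the same nitrogen would be needed to separate the loss of the bromine from the change from aryl to benzyl. Going by these compounds, it also remains open whether a very different group here, such as a longer chain ending in an amine or a carboxylic acid, would move the read-out beyond the scatter.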